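Methyl on the Ring: Expecting the Value of Compound 4

The source may hold more compounds than are shown below. What is called first, only, known or untested is meant among the compounds shown, and "the series" means these compounds.

The three measured compounds were all tested in a functional assay on A549 cells (Homo sapiens) for cytotoxicity, read by CCK-8 assay, with a stated time of 24 h; a higher number here means a weaker inhibitor, a lower number a stronger inhibitor. Compound 1, `C/C(=C\c1cc(-c2ccccc2)cs1)C(N)=O`, gives > 50000 nM, which is a limit of the assay rather than a number. Compound 2, `C/C(=C\c1cc(-c2ccc(C)cc2)cs1)C(N)=O`, gives > 50000 nM, again a limit. Compound 3, `C/C(=C\c1nc(-c2ccccc2)cs1)C(N)=O`, gives > 50000 nM, also a limit.

Compound 4, `C/C(=C\c1nc(-c2ccc(C)cc2)cs1)C(N)=O`, has not yet been measured. It differs from compound 3 by methyl in place of hydrogen on an aromatic carbon. The same change is seen between compound 1 and compound 2, (methyl in place of hydrogen on an aromatic carbon), and there the step that the two limits leave unreadable from compound 1 to compound 2 could not be read because of the limit of > 50000 nM in this assay, at which 3 of the 3 values shown sit. The difference between the core of compound 1 and the core of compound 3 is not broken down here.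

Among the measured compounds shown here, since every value so far sits at the limit, the step that the limit leaves unreadable from compound 3 to compound 4 is expected to be small or unreadable. Compound 4 is expected to give 80000 nM, most likely reported as a limit once more.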

Compound 4, half-maximal inhibitory concentration: > 50000 nM
Compound 4 ended at the assay's limit (the forecaster's own chance of this, stated with the estimate: 85%); the middle value lies beyond the limit too.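

No size can be read for the methyl step between compound 3 and compound 4, because neither value is a true number: the limit of > 50000 nM in this assay, at which 4 of the 4 values shown sit. The compounds shown leave open whether this methyl changes activity at all.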